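A few compounds are considered here, and "the series" means these few. Any claim that something is new, unique, unknown or untested is made for them only; others in the source may bear on it.

Compound 1 `O=c1cc(-c2ccccc2)oc2cc(O)c(OCCCN3CCCCC3)c(O)c12` bears a 3-(piperidin-1-yl)propyl chain on an oxygen of the shared core, flanked by two free hydroxyls. In a functional assay on A549 cells (Homo sapiens) for antiproliferative activity, read by MTT assay, with a stated time of 48 h (on this read-out lower numbers stand for stronger inhibition and higher numbers for weaker inhibition), compound 1 gives > 100000 nM, which is a limit of the assay rather than a number. Compound 1 sits at the limit of > 100000 nM in this assay, at which 2 of the 3 values shown sit. Among the compounds with values here, compound 2 `COc1cc2oc(-c3ccccc3)cc(=O)c2c(O)c1OCCCN1CCCCC1` gives 17000 nM in this assay, and the step of an at least 5.8-fold lower number from compound 1 to compound 2 (0.76 log units; beyond the scatter) is the only measured step that reaches a number. Compound 3 `COc1cc2oc(-c3ccccc3)cc(=O)c2c2c1OCCCCO2` gives > 100000 nM in this assay, which is again a limit.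

Compound 4 `O=c1cc(-c2ccccc2)oc2cc(O)c(OCCCCN3CCCCC3)c(O)c12` differs from compound 1 by (piperidin-1-yl)methyl in place of piperidin-1-yl on a saturated chain carbon, three bonds along the chain from an oxygen on an aromatic ring, so the chain grows from 3-(piperidin-1-yl)propyl to 4-(piperidin-1-yl)butyl. Within the data shown here, no measured step alters this chain; the single step from compound 1 to compound 2 changes a different place, and the two remaining values are limits. Compound 4 is therefore expected to show no step beyond the scatter, as a number no higher from compound 1 to compound 4 (the limit leaves the size open). Compound 4 is estimated at 100000 nM, within 30000 nM to 300000 nM.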

Compound 4, half-maximal inhibitory concentration: 75000 nM
Compound 4: middle estimate off by 1.3-fold (0.12 log units), on the high side; low and high end bracket the measured number.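

Growing the chain from 3-(piperidin-1-yl)propyl to 4-(piperidin-1-yl)butyl, on a saturated chain carbon, three bonds along the chain from an oxygen on an aromatic ring, gives the first measured step at this position in this assay, with an at least 1.3-fold lower number from compound 1 to compound 4 (0.12 log units; that floor lies within the scatter). It also shows that, with both free hydroxyls kept, a change in this chain alone can yield a number rather than a limit. Even so, the size of the step cannot be fixed, and whether it is real remains unsettled, as compound 1 rests on a limit: the limit of > 100000 nM in this assay, at which 2 of the 4 values shown sit.

The compounds shown leave open whether a shorter 2-(piperidin-1-yl)ethyl chain or a longer 5-(piperidin-1-yl)pentyl chain would give a lower or a higher number. They also leave open how a morpholine in place of the piperidine would read, and whether methyl on an oxygen would give a comparable step on the 4-(piperidin-1-yl)butyl chain.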